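Removing a single acetate in a carbamate lactone series

The source may report more compounds than this note shows. Statements on the series, on what has been measured and on what is new or still open speak of the compounds shown alone.

The series is followed in a functional assay on P388 cells (Mus musculus) for cytotoxicity; on this read-out lower numbers stand for stronger inhibition and higher numbers for weaker inhibition. Compound 1 `CCCC[C@H](C)[C@H](OC(N)=O)[C@@H](C)[C@H](O)[C@@H](C)C/C(C)=C\[C@H](C)[C@@H](O)[C@@H](C)CCCC[C@@H]1OC(=O)[C@H](C)[C@@H](O)[C@H]1C` carries free hydroxy groups throughout and gives 309 nM. Compound 2 `CCCC[C@H](C)[C@H](OC(N)=O)[C@@H](C)[C@H](OC(C)=O)[C@@H](C)C/C(C)=C\[C@H](C)[C@@H](OC(C)=O)[C@@H](C)CCCC[C@@H]1OC(=O)[C@H](C)[C@@H](OC(C)=O)[C@H]1C` is the fully acetylated counterpart; in this assay compound 2 returns only a limit, > 7050 nM. Compound 3 `C=C/C=C\[C@H](C)[C@H](OC(N)=O)[C@@H](C)[C@H](O)[C@@H](C)C/C(C)=C\[C@H](C)[C@@H](OC(C)=O)[C@@H](C)/C=C\[C@@H](O)C[C@@H]1OC(=O)C(C)=C[C@H]1C`, which keeps one acetoxy group and differs further in the chain ends and in the lactone, gives 519 nM. Among the two numbers that are not limits compound 3 has the higher one, but its gap to compound 1 lies within the scatter, so no order between the two can be read.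

Compound 4 `C=C/C=C\[C@H](C)[C@H](OC(N)=O)[C@@H](C)[C@H](O)[C@@H](C)C/C(C)=C\[C@H](C)[C@@H](O)[C@@H](C)/C=C\[C@@H](O)C[C@@H]1OC(=O)C(C)=C[C@H]1C` is the not yet measured congener of compound 3. The change is hydrogen in place of acetyl on an oxygen on a saturated carbon.

No step between measured compounds is shown, and no value here can be assigned to a single acetate. Among the measured compounds shown here, what is seen is that the only compound without a numeric result is the fully acetylated compound 2, as stated in the limit of > 7050 nM in this assay, at which 1 of the 3 values shown sits, while the compounds with fewer acetates give numbers. For compound 4 the step of a 1.6-fold lower number from compound 3 to compound 4 (0.20 log units; within the scatter) is therefore expected to be small, toward a lower number if anything, and not clearly beyond the scatter. Compound 4 is estimated at 330 nM, within 110 nM to 1000 nM.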

Compound 4, half-maximal inhibitory concentration: 33.6 nM
Compound 4: middle estimate off by 9.8-fold (0.99 log units), on the high side; the measured number lies below the stated range.
By their numbers in this assay, from the lowest: compound 4; then compounds 1 and 3 (each within the scatter of the next). At a limit, above all of these: compound 2.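

Among the compounds shown here, the acetoxy to hydroxy change gives the first reading of a single place: on an oxygen on a saturated carbon, hydrogen in place of acetyl goes with a 15-fold lower number from compound 3 to compound 4 (1.19 log units; beyond the scatter) in this assay. Compounds 1, 2 and 3 differ from one another in more than one place, so they gave no reading of this kind, and the size of the step at this position is new information. Compound 2, which carries acetyl on each of its three such oxygens, remains a limit and not a number: the limit of > 7050 nM in this assay, at which 1 of the 4 values shown sits.

From the compounds shown here alone, whether a step of this size also applies to the other acetylated oxygens of compound 2, or to the saturated chain ends of compound 1, remains open, since one step on one pair cannot show how far it carries over to another place or another core. Also open, going by these compounds, is whether acetyl is special at this oxygen or whether another group there, such as a methyl ether or a longer acyl chain like butyryl, would read the same way.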